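The source may hold more compounds than are shown below. What is called first, only, known or untested is meant among the compounds shown, and "the series" means these compounds.

For the measured compounds named here, compound 2 `O=C(N/N=C/c1ccc(O)cc1)c1cnccn1` gives 100% in an ADME assay on J774 cells (Mus musculus) for cytotoxicity, read by MTT assay, with a stated time of 48 h, tested at 50 ug/mL (a higher number here means a weaker effect of the compound at the concentration tested, a lower number a stronger effect), the higher of the two numbers measured so far; compound 1 `COc1ccc(/C=N/NC(=O)c2cnccn2)cc1` gives 74%. Compound 3 `CN(C)c1ccc(/C=N/NC(=O)c2cnccn2)cc1` differs from compound 2 by dimethylamino in place of hydroxy on an aromatic carbon. Going by the values given here, the only measured step, a number 26 percentage points higher from compound 1 to compound 2 (beyond the scatter), touched the same oxygen, but it did not replace the hydroxy with a different group, so it bears only loosely here. A move back toward the number of compound 1 is the expectation, as the estimate a number 20 percentage points lower from compound 2 to compound 3 (beyond the scatter) shows. Compound 3 is therefore expected to give 80%, within 55% to 100%.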

Compound 3, a percentage reported as activity, at one concentration (the size of the read-out at that concentration, not a potency): 93%
For compound 3 the middle estimate is 13 percentage points below the measured one; low and high end bracket the measured number.
By their numbers in this assay, from the lowest: compound 1; then compounds 3 and 2 (each within the scatter of the next).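

In this assay, replacing hydroxy with dimethylamino gives a number 7 percentage points lower from compound 2 to compound 3 (within the scatter). Dimethylamino has no hydrogen-bond donor, so losing the donor of hydroxy is not enough on its own to produce the lower number of compound 1, and swapping methoxy for dimethylamino gives a number 19 percentage points higher from compound 1 to compound 3 (beyond the scatter). Among these three compounds, only methoxy stands apart, and nothing available explains this. On these data alone, it remains open whether a chlorine atom, a carboxylic acid or a longer chain such as ethoxy at this place would match compound 1 or compound 2.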